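Second hydroxy on the flavone core: notes on cytotoxicity

The source may report more compounds than this note shows. Statements on the series, on what has been measured and on what is new or still open speak of the compounds shown alone.

The series is read in a functional assay on Malme-3M cells (Homo sapiens) for cytotoxicity, read by MTT assay, with a stated time of 6 days; a higher number here means that more compound is needed for the effect, a lower number that less compound is needed. Compound 1 `O=c1cc(-c2ccc([N+](=O)[O-])cc2)oc2cc(O)ccc12` gives in this assay only a limit of the assay, > 25 ug/mL. Compound 2 `O=c1cc(-c2ccc([N+](=O)[O-])cc2)oc2c(O)c(O)ccc12` gives 3.61 ug/mL in this assay. The change between them is hydroxy in place of hydrogen on an aromatic carbon, and the step is an at least 6.9-fold lower number from compound 1 to compound 2 (0.84 log units; beyond the scatter). Compound 3 `COc1cc(-c2cc(=O)c3ccc(O)cc3o2)cc(OC)c1OC` gives in this assay only a limit of the assay, > 25 ug/mL. The difference between the core of compound 3 and the core of compound 1 is not broken down here. Compound 4 `COc1cc(-c2cc(=O)c3ccc(O)c(O)c3o2)cc(OC)c1OC` has not yet been measured; it differs from compound 3 by hydroxy in place of hydrogen on an aromatic carbon, the same change that turns compound 1 into compound 2, with the place described in the same words. Two of the three values sit at the limit of > 25 ug/mL in this assay, at which 2 of the 3 values shown sit, so the measured step is known only as a lower bound. For compound 4 a step of an at least 4.1-fold lower number from compound 3 to compound 4 (0.61 log units; beyond the scatter) is expected in this assay, resting on the step of an at least 6.9-fold lower number from compound 1 to compound 2 (0.84 log units; beyond the scatter) made by the same change. Compound 4 is estimated at 6 ug/mL in this assay, with a real chance that only a limit is reported again.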

Compound 4, concentration for half-maximal effect: > 25 ug/mL
Compound 4: a limit, no number; the forecaster's own chance of this, stated with the estimate: 35%; at least 4.1-fold (0.61 log units) between middle value and limit.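

In this assay compound 4 gives > 25 ug/mL as a limit of the assay and not a number. Among these compounds, compound 3 also gives only a limit, so no step between compound 3 and compound 4 can be read. Left open is whether hydroxy in place of hydrogen on the core of compound 3 changes the number at all, as most of the series rests on one limit: the limit of > 25 ug/mL in this assay, at which 3 of the 4 values shown sit.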